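Heteroaryl swap on a shared core: working notes

This account rests on a few compounds, and the source may have more. Where it says the series, first, only, none or still open, it means among the compounds named here.

Compound 1 `Nc1ccn(C[C@H](O)[C@H]2OC(=O)C(OCc3ccccc3)=C2OCc2ccccc2)c(=O)n1` and compound 2 `Nc1ccn(CCC2(N)OC(=O)C(OCc3ccccc3)=C2OCc2ccccc2)c(=O)n1` share a core but the difference between the two cores is not broken down here. In a functional assay on MIA PaCa-2 cells (Homo sapiens) for inhibition, read by MTT assay, with a stated time of 72 h (on this read-out higher numbers stand for weaker inhibition and lower numbers for stronger inhibition), compound 1 gives > 100000 nM, which is a limit of the assay and not a number. In this assay compound 2 likewise gives > 100000 nM, again a limit. Compound 3 `NC1(CCn2c(=O)[nH]c(=O)[nH]c2=O)OC(=O)C(OCc2ccccc2)=C1OCc1ccccc1` follows from compound 2 by the change (a group of 9 heavy atoms (3 carbon, 3 nitrogen, 3 oxygen; one six-membered aromatic ring with 3 hetero atoms) in place of a group of 8 heavy atoms (4 carbon, 3 nitrogen, 1 oxygen; one six-membered aromatic ring with 2 hetero atoms), on a saturated chain carbon, two bonds along the chain from a saturated ring carbon). In this assay compound 3 gives > 100000 nM, also a limit. Within the data shown here, the step that the two limits leave unreadable from compound 2 to compound 3 therefore cannot be read, since the limit of > 100000 nM in this assay, at which 3 of the 3 values shown sit, holds for every value so far.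

Compound 4 `O=C1O[C@H]([C@@H](O)Cn2c(=O)[nH]c(=O)[nH]c2=O)C(OCc2ccccc2)=C1OCc1ccccc1` is not yet measured and follows from compound 1 by the change (a group of 9 heavy atoms (3 carbon, 3 nitrogen, 3 oxygen; one six-membered aromatic ring with 3 hetero atoms) in place of a group of 8 heavy atoms (4 carbon, 3 nitrogen, 1 oxygen; one six-membered aromatic ring with 2 hetero atoms), on a saturated chain carbon, two bonds along the chain from an oxygen on a saturated carbon and a saturated ring carbon). The place of this change is described as two bonds along the chain from an oxygen on a saturated carbon and a saturated ring carbon, whereas in the earlier pair it is two bonds along the chain from a saturated ring carbon, so the two are the same kind of change rather than the same change.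

Because the limit of > 100000 nM in this assay, at which 3 of the 3 values shown sit, sits at every value shown, the step that the limit leaves unreadable from compound 1 to compound 4 is expected to stay unreadable in the same way, with compound 4 most likely reported as a limit. For compound 4 the estimate in this assay is 150000 nM, with an expected range from 40000 nM to 500000 nM.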

Compound 4, half-maximal inhibitory concentration: > 100000 nM
Compound 4 ended at the assay's limit; the forecaster's own chance of this, stated with the estimate: 85%; the middle value lies beyond the limit too.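

In this assay compound 4 gives > 100000 nM, which is a limit of the assay and not a number. No step can be read from compound 1 to compound 4, or for any other pair, because every value shown sits at the same limit: the limit of > 100000 nM in this assay, at which 4 of the 4 values shown sit.

The compounds shown leave open how the two six-membered aromatic groups, or the two cores, compare in this assay.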